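The source may hold more compounds than are shown below. What is called first, only, known or untested is meant among the compounds shown, and "the series" means these compounds.

In an ADME assay on HEK293 cells (Homo sapiens) for cytotoxicity, read by resazurin assay, with a stated time of 48 h (a lower number here means that less compound is tolerated, a higher number that more compound is tolerated), compound 3 (`COc1ccc(S(=O)(=O)Nc2ccc3oc(-c4ccccc4)nc3c2)cc1`) gives 91000 nM. Compound 1 (`O=S(=O)(Nc1ccc2oc(-c3ccccc3)nc2c1)c1ccccc1F`) gives 72000 nM, which makes a 1.3-fold higher number from compound 1 to compound 3 (0.10 log units; within the scatter). Compound 2 (`O=S(=O)(Nc1ccc2oc(-c3ccccc3)nc2c1)c1cccc(O)c1`) is known only as a limit of the assay, > 100000 nM. Compound 4 (`O=S(=O)(Nc1ccc2oc(-c3ccccc3)nc2c1)c1ccc(Cl)c(Cl)c1`) has 3,4-dichlorophenyl in place of 4-methoxyphenyl on a sulfonyl sulfur. Two measured changes at this same place bear on it: a 1.3-fold higher number from compound 1 to compound 3 (0.10 log units; within the scatter), and an at least 1.3-fold higher number from compound 1 to compound 2 (0.14 log units; that floor lies within the scatter). Among the measured compounds shown here, neither shows a change beyond the scatter, although no chlorinated group has yet been tested, so no step beyond the scatter is expected here. The expected change is a 1.5-fold lower number from compound 3 to compound 4 (0.17 log units; within the scatter). For compound 4 the estimated value is 62000 nM, with an expected range from 25000 nM to 100000 nM.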

Compound 4, half-maximal cytotoxic concentration: 71000 nM
Estimate against measurement, compound 4: 1.1-fold (0.06 log units) below, and the stated range covers the measured number.
By their numbers in this assay, from the lowest: compounds 4, 1 and 3 (each within the scatter of the next). At a limit, above all of these: compound 2.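

Among the compounds shown here, with 3,4-dichlorophenyl, the first chlorinated group at this place, the sulfonyl sulfur still shows no change beyond the scatter in this assay: there is a 1.3-fold lower number from compound 3 to compound 4 (0.11 log units; within the scatter), and a 1.0-fold lower number from compound 1 to compound 4 (0.01 log units; within the scatter). Swapping the oxygen-bearing 4-methoxyphenyl, with its hydrogen-bond acceptor, for this group with none therefore leaves the number within the scatter. Compound 2 remains a limit, so an at least 1.4-fold lower number from compound 2 to compound 4 (0.14 log units; that floor lies within the scatter) gives only a floor for that step, and its full size stays unknown: the limit of > 100000 nM in this assay, at which 1 of the 4 values shown sits.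

Still open, as far as these compounds go, is whether an amine or a carboxylic acid in this place would move the number beyond the scatter.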